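The source may report more compounds than this note shows. Statements on the series, on what has been measured and on what is new or still open speak of the compounds shown alone.

For the measured compounds named here, two measured compounds define the series so far. Compound 1 `CC(C)n1ncc2c(C(=O)NCc3ccccc3)cccc21` carries a benzyl amide on the shared core; in a functional assay on MCF7 cells (Homo sapiens) for inhibition, read by MTT assay, with a stated time of 72 h (on this read-out higher numbers stand for weaker inhibition and lower numbers for stronger inhibition), compound 1 reaches only the limit of the assay, > 40000 nM. Compound 2 `Cc1ccc(-n2cc(CNC(=O)c3cccc4c3cnn4C(C)C)nn2)c(C)c1` extends the amide through a triazole bearing 2,4-dimethylphenyl; in this assay compound 2 likewise returns only a limit, > 40000 nM. Both values shown are limits, so compound 2 stands on no scale of numbers: the limit of > 40000 nM in this assay, at which 2 of the 2 values shown sit. Going by the values given here, no step between measured compounds can be computed.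

Compound 3 `CC(C)n1ncc2c(C(=O)NCc3cn(-c4ccc(F)cc4)nn3)cccc21` differs from compound 2 by 4-fluorophenyl in place of 2,4-dimethylphenyl on an aromatic nitrogen of the five-membered aromatic ring with three nitrogen. Among the compounds with values here, with no measured step to weigh, no move beyond the scatter is expected in this assay from this exchange, in either direction. The expected step that the limit leaves unreadable from compound 2 to compound 3 is flat. Compound 3 is expected at 60000 nM in this assay, within 20000 nM to 200000 nM, most likely reported again as a limit.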

Compound 3, half-maximal inhibitory concentration: > 40000 nM
Compound 3 was reported as a limit; the forecaster's own chance of this, stated with the estimate: 85%; the middle value is on the limit's open side.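

No step can be read from compound 2 to compound 3 in this assay, because both results are limits and neither is a number: the limit of > 40000 nM in this assay, at which 3 of the 3 values shown sit.

The compounds shown leave open whether any aryl group on that aromatic nitrogen, or any other change to the shared core, would give a measurable value in this assay.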